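Triazene amides in a HeLa cytotoxicity series: aryl to chloromethyl

A few compounds are considered here, and "the series" means these few. Any claim that something is new, unique, unknown or untested is made for them only; others in the source may bear on it.

Compound 1, `O=C(c1ccccc1F)N(/N=N/c1ccc([N+](=O)[O-])cc1C(F)(F)F)c1ccc([N+](=O)[O-])cc1C(F)(F)F`, 800 nM in a functional assay on HeLa cells (Homo sapiens) for cytotoxicity, read by MTT assay, with a stated time of 72 h; a lower number here means a stronger inhibitor, a higher number a weaker inhibitor.
Compound 2, `O=C(c1cccc(F)c1)N(/N=N/c1ccc([N+](=O)[O-])cc1C(F)(F)F)c1ccc([N+](=O)[O-])cc1C(F)(F)F`, 880 nM in this assay.

Going by the values given here, compound 2 gives the higher of the two numbers in this assay, but its only neighbour is compound 1, and the step of a 1.1-fold higher number from compound 1 to compound 2 (0.04 log units; within the scatter) lies within the scatter, so the two compounds cannot be ordered.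

Compound 3, `O=C(CCl)N(/N=N/c1ccc([N+](=O)[O-])cc1C(F)(F)F)c1ccc([N+](=O)[O-])cc1C(F)(F)F`, carries the change (chloromethyl in place of 3-fluorophenyl on a carbonyl carbon). Among the compounds with values here, the one measured step, from compound 1 to compound 2, moved a fluorine around the phenyl ring; it says nothing about removing the phenyl ring altogether and putting a chloromethyl in its place, so no measured step bears on this change. The direction and size of the step in this assay are therefore open, and the expected step of a 1.1-fold lower number from compound 2 to compound 3 (0.04 log units; within the scatter) is set at no change with a wide range. Compound 3 is expected to give 800 nM, between 150 nM and 4000 nM.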

Compound 3, half-maximal inhibitory concentration: 800 nM
Compound 3: middle estimate and measured number agree at the digits printed; low and high end bracket the measured number.
By their numbers in this assay, from the lowest: compounds 1, 3 and 2 (each within the scatter of the next).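

Putting an open-chain group on the carbonyl carbon does not separate the compounds in this assay: the steps of a 1.1-fold lower number from compound 2 to compound 3 (0.04 log units; within the scatter) and no change at the digits printed from compound 1 to compound 3 (within the scatter) both lie within the scatter. This position, shown until now only with fluorophenyl groups, therefore also tolerates chloromethyl, with 2 heavy atoms and no ring in place of the 7 heavy atoms of 3-fluorophenyl, without a readable difference in this measurement. No measurement at hand explains why the aromatic ring can be exchanged with so little effect on the number.

As far as these compounds go, what a methyl, a longer chain or an amine on this carbonyl carbon would give remains open, as does whether the chlorine of chloromethyl plays any part. All three compounds share the rest of the core, so they also leave open how far its other parts bear on the number in this assay.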